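The source may hold more compounds than are shown below. What is called first, only, known or untested is meant among the compounds shown, and "the series" means these compounds.

Compound 1 `CC(C)OC(=O)C1=CN(C(=O)c2cccc(C(F)(F)F)c2)CC(C)(C)c2cc(C#N)[nH]c21` holds the lowest of the two numbers recorded so far: in an assay on HEK293 cells for agonist activity at Bile acid receptor (Homo sapiens), read by a luciferase reporter (a lower number here means that less compound is needed, a higher number that more compound is needed for the effect), compound 1 gives 8.5 nM. Among the compounds with values here, the only other measured member, compound 2 `CC(C)OC(=O)C1CN(C(=O)c2ccc(C#N)cc2)CC(C)(C)c2cc(C#N)[nH]c21`, gives 5700 nM in this assay; the two values lie far apart, but compound 2 differs from compound 1 in more than one place, so no single step has been worked out between them. Compound 3 `CC(C)OC(=O)C1=CN(C(=O)c2ccc(C#N)cc2)CC(C)(C)c2cc(C#N)[nH]c21` has not been measured. It differs from compound 1 at one place only: 4-cyanophenyl in place of 3-(trifluoromethyl)phenyl on a carbonyl carbon. Compound 2 also carries 4-cyanophenyl at that carbonyl carbon and differs from compound 1 in the shared core as well, so its number cannot be split between the two changes. A rise beyond the scatter is expected for a 7.1-fold higher number from compound 1 to compound 3 (0.85 log units; beyond the scatter), though smaller than the gap to compound 2. Compound 3 is estimated at 60 nM in this assay, with a range of 10 nM to 400 nM.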

Compound 3, half-maximal effective concentration: 35 nM
Estimate against measurement, compound 3: 1.7-fold (0.23 log units) above; low and high end bracket the measured number.
By their numbers in this assay, from the lowest: compound 1; then compound 3; then compound 2.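

At the carbonyl carbon, the exchange of 3-(trifluoromethyl)phenyl for 4-cyanophenyl is a modest step in this assay: a 4.1-fold higher number from compound 1 to compound 3 (0.61 log units; beyond the scatter) leaves compound 3 far closer to compound 1 than to compound 2. With 4-cyanophenyl held constant and only the shared core differing, compound 3 gives 35 nM and compound 2 gives 5700 nM in this assay, which places most of the wide gap first seen between compound 1 and compound 2 with the core difference rather than with this carbonyl substituent. No supporting data bear on the reason for the size of this step.

Open, from the compounds shown here alone, is whether the step follows the change from trifluoromethyl to nitrile or the changed place on the phenyl ring, as both change together here. Also open, going by these compounds, is how a phenyl ring carrying an amine or a carboxylic acid would behave at this carbonyl carbon.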